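This account rests on a few compounds, and the source may have more. Where it says the series, first, only, none or still open, it means among the compounds named here.

In a functional assay on UACC-62 cells (Homo sapiens) for inhibition, read by sulforhodamine B assay, with a stated time of 48 h (a lower number here means a stronger inhibitor of growth, a higher number a weaker inhibitor of growth), compound 1 `O=C(Nc1cccc(-n2cc(-c3ccncc3)c(-c3ccc(Cl)c(O)c3)n2)c1)Nc1cccc(C(F)(F)F)c1` gives 1650 nM, the highest number among the three measured compounds. Compound 2 `O=C(Nc1cccc(-n2cc(-c3ccncc3)c(-c3ccc(Cl)c(O)c3)n2)c1)Nc1ccc(Cl)c(Cl)c1` gives 1110 nM, and a 1.5-fold lower number from compound 1 to compound 2 (0.17 log units; within the scatter). Compound 3 `COc1cc(-c2nn(-c3cccc(NC(=O)Nc4cccc(C(F)(F)F)c4)c3)cc2-c2ccncc2)ccc1Cl` gives 725 nM, and a 2.3-fold lower number from compound 1 to compound 3 (0.36 log units; beyond the scatter). Compound 4 `O=C(Nc1cccc(-n2cc(-c3ccncc3)c(-c3ccc(Cl)c(O)c3)n2)c1)Nc1cc(C(F)(F)F)cc(C(F)(F)F)c1` differs from compound 1 by trifluoromethyl in place of hydrogen on an aromatic carbon. The step from compound 1 to compound 2 bears on this most, since it also reworks the aryl group on the same amide-type nitrogen and stayed within the scatter; the step from compound 1 to compound 3 alters a different part of the shared core. A step in this assay no larger than modest is therefore expected, without a clear direction. Compound 4 is estimated at 1400 nM, with a range from 600 nM to 3300 nM, meaning a 1.2-fold lower number from compound 1 to compound 4 (0.07 log units; within the scatter).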

Compound 4, concentration for 50% growth inhibition: 749 nM
For compound 4 the middle estimate is 1.9-fold (0.27 log units) above the measured one; measured number inside the range.
By their numbers in this assay, from the lowest: compounds 3, 4, 2 and 1 (each within the scatter of the next, the first and the last beyond it).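

In this assay, among these compounds, placing trifluoromethyl on an aromatic carbon, meta to the trifluoromethyl group already present, gives a 2.2-fold lower number from compound 1 to compound 4 (0.34 log units; beyond the scatter) and is the first change to this aryl group that goes beyond the scatter. The swap to 3,4-dichlorophenyl, with a 1.5-fold lower number from compound 1 to compound 2 (0.17 log units; within the scatter), did not. So this carbon can carry an added group, and the number still falls modestly. Nothing available explains the change. As far as these compounds go, whether a fluorine atom, a methoxy group or an amine at this carbon would do the same remains open.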